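The source may report more compounds than this note shows. Statements on the series, on what has been measured and on what is new or still open speak of the compounds shown alone.

Working notes on the series. Among the measured compounds shown here, compound 1 `COc1ccc(-c2c(O)nc3cc(Cl)c([N+](=O)[O-])cc3c2OCCC2CCCCN2)cc1OC` is one of two compounds measured in a functional assay on cells (Pituitary gland cell) for antagonist activity at Gonadotropin-releasing hormone receptor (Rattus norvegicus); on this read-out lower numbers stand for stronger inhibition and higher numbers for weaker inhibition; compound 1 gives 600 nM, the higher of the two numbers. For the measured compounds named here, compound 2 `Cc1cc(C)cc(-c2c(O)nc3cc(Cl)c(NC(=O)Nc4ncccn4)cc3c2OCCC2CCCCN2)c1` gives 6 nM in this assay, a far lower number, and the gap between the two lies well beyond the usual scatter; no single-site step connects these two compounds, so only the two numbers themselves are known.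

The change under study runs from compound 1 to compound 3 `O=[N+]([O-])c1cccc(-c2c(O)nc3cc(Cl)c([N+](=O)[O-])cc3c2OCCC2CCCCN2)c1`: 3-nitrophenyl in place of 3,4-dimethoxyphenyl on an aromatic carbon. The group enters on an aromatic carbon of the shared core, ortho to a 2-(piperidin-2-yl)ethoxy group and ortho to a hydroxy group, where the 3,4-dimethoxyphenyl of compound 1 stood. Going by the values given here, no measured pair shows this exchange, so the expectation rests on compound 1 alone. A small step toward a higher number is expected, a 1.7-fold higher number from compound 1 to compound 3 (0.22 log units; within the scatter), and it may not exceed the scatter. Compound 3 is estimated at 1000 nM, within 300 nM to 4000 nM.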

Compound 3, half-maximal inhibitory concentration: 100 nM
Compound 3: middle estimate off by 10-fold (1.00 log units), on the high side, and the stated range ends above it.
By their numbers in this assay, from the lowest: compound 2; then compound 3; then compound 1.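

In this assay, the aryl group on this aromatic carbon, ortho to a hydroxy group and ortho to a 2-(piperidin-2-yl)ethoxy group, proves able to shift the read-out: 3-nitrophenyl in place of 3,4-dimethoxyphenyl gives a 6.0-fold lower number from compound 1 to compound 3 (0.78 log units; beyond the scatter). The step is beyond the scatter, although leaving and entering groups share a six-membered aromatic ring of carbon only and the same counts of hydrogen-bond donors and acceptors. Nothing available bears on the reason for this step.

Among the compounds shown here, with only this one exchange at the position, the gain cannot be divided between adding the nitro group and removing the two methoxy groups, and plain phenyl or a phenyl bearing a single methoxy or a nitrile would help to separate them. From the compounds shown here alone, compound 2 differs from compound 3 in more than one place, so whether the step carries over to the substituents of compound 2 stays open.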